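Methyl added to the phenyl group of compound 2

This account rests on a few compounds, and the source may have more. Where it says the series, first, only, none or still open, it means among the compounds named here.

Measured compounds:
compound 1 `COc1ccc(C(=O)NNC(=S)Nc2csc(-c3ccc(C)cc3)c2)cc1` 11000 nM
compound 2 `O=C(NNC(=S)Nc1csc(-c2ccccc2)c1)c1ccc(O)cc1` 71000 nM

In a functional assay on SK-MEL-28 cells (Homo sapiens) for inhibition, read by colorimetric assay and MTT assay, with a stated time of 72 h (a higher number here means a weaker inhibitor, a lower number a stronger inhibitor), compound 2 gives 71000 nM, the higher of the two numbers, while compound 1 gives 11000 nM; compounds 1 and 2 differ in two places, so neither change is isolated. Compound 3 `Cc1ccc(-c2cc(NC(=S)NNC(=O)c3ccc(O)cc3)cs2)cc1` differs from compound 2 by methyl in place of hydrogen on an aromatic carbon. The effect of this change alone is not shown by the measured pair. A modest move toward a lower number, around the edge of the scatter, is the expected step from compound 2 to compound 3, a 2.0-fold lower number from compound 2 to compound 3 (0.31 log units; beyond the scatter). For compound 3 the estimated value in this assay is 35000 nM, within 12000 nM to 100000 nM.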

Compound 3, half-maximal inhibitory concentration: 46000 nM
For compound 3 the middle estimate is 1.3-fold (0.12 log units) below the measured one, within the range that was stated.
By their numbers in this assay, from the lowest: compound 1; then compounds 3 and 2 (each within the scatter of the next).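

In this assay the change from phenyl to 4-methylphenyl, taken alone, comes to a 1.5-fold lower number from compound 2 to compound 3 (0.19 log units; within the scatter) and so does not separate the two compounds. Within the data shown here, with the 4-methylphenyl group held fixed, hydrogen in place of methyl on the oxygen gives a 4.2-fold higher number from compound 1 to compound 3 (0.62 log units; beyond the scatter) and is the single change here that lies beyond the scatter. Nothing available explains the size of either step.

On these data alone, it remains open whether an amine or a carboxylic acid on the phenyl ring, or a longer chain on that oxygen, would shift the number beyond the scatter.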